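Chloro in place of methyl on the shared core

A few compounds are considered here, and "the series" means these few. Any claim that something is new, unique, unknown or untested is made for them only; others in the source may bear on it.

In a functional assay on MCF7 cells (Homo sapiens) for inhibition, read by MTT assay, with a stated time of 72 h (on this read-out lower numbers stand for stronger inhibition and higher numbers for weaker inhibition), compound 1 `c1ccc2[nH]c(-c3ccc4n[se]nc4c3)nc2c1` gives 15400 nM and compound 2 `Cc1ccc2nc(-c3ccc4n[se]nc4c3)[nH]c2c1` gives 4100 nM, the lower of the two numbers. Among the compounds with values here, the only measured step is a 3.8-fold lower number from compound 1 to compound 2 (0.57 log units; beyond the scatter), a modest change beyond the scatter, with methyl in place of hydrogen on an aromatic carbon. Compound 3 `Clc1ccc2nc(-c3ccc4n[se]nc4c3)[nH]c2c1` has chloro in place of methyl on an aromatic carbon. Within the data shown here, no measured compound carries chloro, so the evidence is indirect. Among the measured compounds shown here, the step to compound 2, a 3.8-fold lower number from compound 1 to compound 2 (0.57 log units; beyond the scatter), shows only that a change at this carbon can shift the number. It gives no direction for this exchange, and no step beyond the scatter is expected in this assay. The expected change is small, a 1.2-fold lower number from compound 2 to compound 3 (0.07 log units; within the scatter). For compound 3 the estimate is 3500 nM, with an expected range of 1500 nM to 8500 nM.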

Compound 3, half-maximal inhibitory concentration: 26300 nM
Compound 3: the middle estimate sits 7.5-fold (0.88 log units) below what was measured; the measured number lies above the stated range.
By their numbers in this assay, from the lowest: compound 2; then compounds 1 and 3 (each within the scatter of the next).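

In this assay, methyl and chloro are not interchangeable at this aromatic carbon: the exchange gives a 6.4-fold higher number from compound 2 to compound 3 (0.81 log units; beyond the scatter), even though each group has a single heavy atom. Chloro in place of hydrogen gives a 1.7-fold higher number from compound 1 to compound 3 (0.23 log units; within the scatter), so the lower number seen with methyl is not shared by chloro, and substitution at this carbon does not by itself lower the number. The data at hand offer no explanation for the difference between methyl and chloro.

Going by these compounds, whether the lower number seen with methyl carries over to a longer chain such as ethyl, to a methoxy group or to an amine at this carbon remains open, as does whether fluoro would track chloro. On these data alone, with only methyl and chloro at this one carbon, no trend across groups can be drawn, and the other carbons of the shared core remain unexplored here.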